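The compounds below may be only part of what the source reports. "The series", "measured", "known", "first", "only" and "open" are said of these compounds alone.

Going by the values given here, in a physicochemical assay for lipophilicity (on this read-out higher numbers stand for higher lipophilicity and lower numbers for lower lipophilicity), compound 2 `Cn1nccc1-c1cc(C(F)(F)F)ccc1[C@H]1CCOc2cc(S(=O)(=O)Nc3cccc(F)n3)ccc21` gives 3.6, the lower of the two numbers so far, and compound 1 `Cc1nc(-c2cc(C(F)(F)F)ccc2[C@H]2CCOc3cc(S(=O)(=O)Nc4cccc(F)n4)ccc32)co1` gives 4. Compound 3 `Cn1nccc1-c1cc(C(F)(F)F)ccc1[C@H]1CCOc2cc(S(=O)(=O)Nc3cccnn3)ccc21` shares the core of compound 2 and differs by pyridazin-3-yl in place of 6-fluoropyridin-2-yl on a sulfonamide nitrogen, with pyridazin-3-yl in place of 6-fluoropyridin-2-yl on a sulfonamide nitrogen. Among the compounds with values here, the only measured step, a number 0.40 log units lower from compound 1 to compound 2 (beyond the scatter), is modest and sits on an aromatic carbon, so it offers only a loose guide. Within the data shown here, no step at the sulfonamide nitrogen has been measured. A downward move larger than that step is expected, a number 0.80 log units lower from compound 2 to compound 3 (beyond the scatter). The estimated value for compound 3 is 2.8, with a range of 2.2 to 3.4.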

Compound 3, distribution coefficient: 2.2
For compound 3 the middle estimate is 0.60 log units above the measured one, within the range that was stated.
By their numbers in this assay, from the lowest: compound 3; then compound 2; then compound 1.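

In this assay, going by these compounds alone, the sulfonamide nitrogen gives the first reading at this position, a number 1.40 log units lower from compound 2 to compound 3 (beyond the scatter), a larger move than the one on the aromatic carbon, a number 0.40 log units lower from compound 1 to compound 2 (beyond the scatter). The change removes a fluorine-bearing ring with one hetero atom and brings in a ring with two hetero atoms, and this single step cannot separate those two differences. Nothing at hand accounts for the size of the step.

Still open, going by these compounds, is where plain pyridin-2-yl or pyrimidin-2-yl on a sulfonamide nitrogen would fall relative to compound 2 and compound 3. Also open, on these data alone, is whether pyridazin-3-yl gives a similar step with 2-methyl-1,3-oxazol-4-yl on the aromatic carbon.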